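The source may hold more compounds than are shown below. What is called first, only, known or untested is meant among the compounds shown, and "the series" means these compounds.

Measured so far in an ADME assay on MT4 cells (Homo sapiens) for cytotoxicity, read by MTT assay, with a stated time of 96 h (a higher number here means that more compound is tolerated, a lower number that less compound is tolerated), are two compounds:
- compound 1 `NS(=O)(=O)c1ccc(N2N=C(c3ccc(Oc4ccccc4)cc3)CC2c2cccc(F)c2)cc1` gives 25000 nM
- compound 2 `NS(=O)(=O)c1ccc(N2N=C(c3ccc(Oc4ccccc4)cc3)CC2c2ccccc2F)cc1` gives 36000 nM

Compound 2 stands level with compound 1 within the scatter. Among the compounds with values here, compound 3 `NS(=O)(=O)c1ccc(N2N=C(c3ccc(Oc4ccccc4)cc3)CC2c2ccc(Cl)cc2)cc1` has 4-chlorophenyl in place of 2-fluorophenyl on a saturated ring carbon and no measured compound carries that group. Within the data shown here, the only guide is a 1.4-fold higher number from compound 1 to compound 2 (0.16 log units; within the scatter) and that small step involved a different swap on the same carbon. No step beyond the scatter is therefore expected in this assay here. The expected change is a 1.2-fold lower number from compound 2 to compound 3 (0.08 log units; within the scatter) and remains a tentative call. For compound 3 the estimate is 30000 nM with 12000 nM to 70000 nM as its expected range.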

Compound 3, half-maximal cytotoxic concentration: 9000 nM
The estimate for compound 3 lay 3.3-fold (0.52 log units) above the measured number; measured number outside the range, below it.
By their numbers in this assay, from the lowest: compound 3; then compounds 1 and 2 (each within the scatter of the next).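

In this assay the swap to 4-chlorophenyl gives a 4.0-fold lower number from compound 2 to compound 3 (0.60 log units; beyond the scatter) and also a 2.8-fold lower number from compound 1 to compound 3 (0.44 log units; beyond the scatter) on this saturated ring carbon. The two fluorophenyl compounds had shown no step beyond the scatter, so this is the first sign that the group at this position can change how much compound the cells tolerate. No measurement shown explains this shift.

Compound 3 differs from both fluorophenyl compounds in its halogen and in where that halogen sits, so the two changes cannot be told apart. A 4-fluorophenyl or 2-chlorophenyl group would separate them.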